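Three Limits at the Top and One Benzyl Analogue

The source may report more compounds than this note shows. Statements on the series, on what has been measured and on what is new or still open speak of the compounds shown alone.

Compound 1 `CCOC(=O)C(C)C(O)(c1ccc(OC)c(OC)c1OC)c1cccc2ccccc12` was examined in a functional assay on MCF7 cells (Homo sapiens) for inhibition, read by sulforhodamine B assay, with a stated time of 48 h; a lower number here means a stronger inhibitor, a higher number a weaker inhibitor. In this assay compound 1 gives only a limit of the assay, > 20000 nM, and not a number. Compound 2 `COc1ccc(/C(=N/OC(C)=O)c2cccc3ccccc23)c(OC)c1OC` likewise returns a limit in this assay, > 20000 nM. Compound 3 `COc1cc(COC(c2ccc(OC)c(OC)c2OC)c2cccc3ccccc23)cc(OC)c1` also returns a limit in this assay, > 20000 nM. Within the data shown here, compound 1 therefore stands nowhere apart from its two companions: all three values sit at the limit of > 20000 nM in this assay, at which 3 of the 3 values shown sit, and no measured step between any two of them can be drawn, so nothing is known about how large a single change moves the read-out.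

Compound 4 `COc1ccc(C(O)(Cc2ccccc2)c2cccc3ccccc23)c(OC)c1OC` has not yet been measured. It differs from compound 1 in one place: benzyl in place of 1-(ethoxycarbonyl)ethyl on a saturated chain carbon bound to two aromatic carbons and an oxygen on a saturated carbon. Among the measured compounds shown here, with no measured step to lean on, the size of the step in this assay can only be guessed; the most plausible expectation is no change beyond the usual scatter, with compound 4 remaining at or near the same limit, and the expected step is a step that the limit leaves unreadable from compound 1 to compound 4. Compound 4 is accordingly estimated to give 25000 nM in this assay, within a range from 7000 nM to 90000 nM.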

Compound 4, half-maximal inhibitory concentration: 10600 nM
For compound 4 the middle estimate is 2.4-fold (0.37 log units) above the measured one, within the range that was stated.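

Among these compounds, with benzyl on a saturated chain carbon bound to two aromatic carbons and an oxygen on a saturated carbon, compound 4 gives 10600 nM in this assay, the first actual number, so a change at this place can bring the read-out inside the measurable range. The change replaces an open chain carrying a double bond outside aromatic rings with a six-membered aromatic ring of carbon only, and it reads as an at least 1.8-fold lower number from compound 1 to compound 4 (0.27 log units; that floor lies within the scatter), which bounds the step from one side only and gives a floor that does not by itself exceed the usual variation. The true size of the step stays unread, since the value of compound 1 is a limit of the assay and not a number: the limit of > 20000 nM in this assay, at which 3 of the 4 values shown sit.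

The compounds shown leave open whether the aromatic ring of benzyl or the absence of the ethoxycarbonyl group matters here, a question that a carboxylic acid, an amine or a simple longer alkyl chain at this place could help to separate. Also open, going by these compounds, is how a methoxy group or a fluorine on the benzyl ring would move the read-out.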